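This account rests on a few compounds, and the source may have more. Where it says the series, first, only, none or still open, it means among the compounds named here.

Measured so far:
- compound 1 `CSc1ccccc1-c1ncc(C(=O)O)c(=O)[nH]1` gives > 20 mg/kg (a limit)
- compound 2 `CC1Cc2cccc(-c3ncc(C(=O)O)c(=O)[nH]3)c2O1` gives 5 mg/kg
- compound 3 `CCOc1ccc([N+](=O)[O-])cc1-c1ncc(C(=O)O)c(=O)[nH]1` gives 25 mg/kg

All three share one core and were tested in a functional assay on the whole organism (strain Sprague-Dawley) for inhibition, with Rattus norvegicus as the target, with a stated time of 10 min (a higher number here means that more compound is needed for the effect, a lower number that less compound is needed), under the same conditions. Compound 1 stands at > 20 mg/kg and this is a limit, not a number. Of the two true numbers, compound 3 has the higher at 25 mg/kg and compound 2 has the lower at 5 mg/kg with a gap beyond the scatter.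

The next compound is compound 4 `CCOc1ccc(S(=O)(=O)N(CC)CC)cc1-c1ncc(C(=O)O)c(=O)[nH]1` which carries diethylsulfamoyl in place of nitro on an aromatic carbon, para to an ethoxy group (diethylsulfamoyl in place of nitro on an aromatic carbon). The rest of the structure of compound 3 stays as it is.

Going by the values given here, no measured pair shows a change at this place, so the only anchor is compound 3 at 25 mg/kg with no trend to extend. In this assay no step beyond the scatter is expected in either direction. The expected size is a 1.3-fold lower number from compound 3 to compound 4 (0.10 log units; within the scatter) and this estimate is loose. For compound 4 the estimated dose is 20 mg/kg with an expected range from 7 mg/kg to 60 mg/kg on present evidence.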

Compound 4, dose for 50% inhibition: 40 mg/kg
The estimate for compound 4 lay 2.0-fold (0.30 log units) below the measured number, within the range that was stated.
By their numbers in this assay, from the lowest: compound 2; then compounds 3 and 4 (each within the scatter of the next).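

At the aromatic carbon para to an ethoxy group, the series now has its first change that can be read as a single step in this assay: diethylsulfamoyl in place of nitro gives a 1.6-fold higher number from compound 3 to compound 4 (0.20 log units; within the scatter). This place therefore takes a group of 8 heavy atoms in place of one of 3, with the hydrogen-bond acceptor count unchanged and no hydrogen-bond donor on either side, without a step beyond the scatter. Nothing in this assay separates these two groups, and a single pair at this place gives no trend.

Compound 1 stands only as a limit and offers no number for comparison here: the limit of > 20 mg/kg in this assay, at which 1 of the 4 values shown sits.

From the compounds shown here alone, whether an amine or an unsubstituted sulfamoyl group at this place would move the dose beyond the scatter remains open, as does the effect of replacing the ethoxy group while diethylsulfamoyl is held in place.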